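This account rests on a few compounds, and the source may have more. Where it says the series, first, only, none or still open, it means among the compounds named here.

Measured:
- compound 1 `CC(=O)ON(C)/C=C\C(=O)c1ccc(OCc2ccccc2)cc1`: > 25000 nM
- compound 2 `CC(=O)ON(C)/C=C\C(=O)c1ccc([N+](=O)[O-])cc1`: > 25000 nM

In an assay on RBL-1 cells for inhibition of Polyunsaturated fatty acid 5-lipoxygenase (Rattus norvegicus) (on this read-out lower numbers stand for stronger inhibition and higher numbers for weaker inhibition), compound 1 gives > 25000 nM, a limit of the assay. Compound 2 gives > 25000 nM, also a limit. Both values sit at the limit of > 25000 nM in this assay, at which 2 of the 2 values shown sit. Among the compounds with values here, the only measured step, a step that the two limits leave unreadable from compound 1 to compound 2, therefore carries no readable size or direction.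

Compound 3 `CC(=O)ON(C)/C=C\C(=O)c1ccc(-c2ccccc2)cc1` differs from compound 2 by phenyl in place of nitro on an aromatic carbon. Within the data shown here, no measured step in this assay speaks to this exchange, and the limits on compound 1 and compound 2 set no direction.

Compound 3 is expected near the same limit, about 30000 nM (range 8000 nM to 100000 nM). The expected step is a step that the limit leaves unreadable from compound 2 to compound 3.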

Compound 3, half-maximal inhibitory concentration: > 25000 nM
Compound 3 ended at the assay's limit; the forecaster's own chance of this, stated with the estimate: 65%; the middle value does not contradict the limit.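

No step can be read among compound 1, compound 2 and compound 3, since all three values are limits of the assay: the limit of > 25000 nM in this assay, at which 3 of the 3 values shown sit.

The compounds shown leave open whether any group on that aromatic carbon of the shared core gives a measurable inhibition.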